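This account rests on a few compounds, and the source may have more. Where it says the series, first, only, none or still open, it means among the compounds named here.

Measured compounds:
Compound 1 `CNC(=O)c1cc(C(=O)NC2CC2)cn(Cc2cccc3cc[nH]c23)c1=O`: in a physicochemical assay for solubility (on this read-out lower numbers stand for lower solubility and higher numbers for higher solubility), compound 1 gives >= 144 ug/mL, a limit of the assay and not a number.
Compound 2 `CNC(=O)c1cc(C(=O)NC2CC2)cn([C@H](C)c2ccccc2)c1=O`: in this assay compound 2 gives >= 168 ug/mL, likewise a limit of the assay.
Compound 3 `CNC(=O)c1cc(C(=O)NC2CC2)cn(Cc2nccc3[nH]ccc23)c1=O`: in this assay compound 3 gives 73 ug/mL.

Going by the values given here, compound 3 thus holds the only number among the three values. Compound 1 sits at the limit of >= 144 ug/mL in this assay, at which 1 of the 3 values shown sits. Compound 2 sits at the limit of >= 168 ug/mL in this assay, at which 1 of the 3 values shown sits. Compound 4 `CNC(=O)c1cc(C(=O)NC2CC2)cn(Cc2ccc(F)cc2)c1=O` has not been measured. The change is a group of 7 heavy atoms (6 carbon, 1 fluorine; one six-membered aromatic ring of carbon only) in place of a group of 9 heavy atoms (7 carbon, 2 nitrogen; one five-membered aromatic ring with 1 hetero atom, one six-membered aromatic ring with 1 hetero atom), on a saturated chain carbon bound to an aromatic nitrogen. Among the compounds with values here, the one measured step at the same place is an at least 1.9-fold lower number from compound 1 to compound 3 (0.29 log units; that floor lies within the scatter), and its floor lies within the scatter, so it gives only a weak pointer. Compound 4 returns to a six-membered aromatic ring of carbon only and sheds the five-membered aromatic ring with its hydrogen-bond donor and acceptor, so a number in the region of compounds 1 and 2 is expected rather than below compound 3. For compound 4 the expected step is a 2.1-fold higher number from compound 3 to compound 4 (0.31 log units; beyond the scatter). Compound 4 is estimated at 150 ug/mL, with a range from 60 ug/mL to 320 ug/mL.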

Compound 4, solubility: >= 162 ug/mL
Compound 4 gave a limit, no number (the forecaster's own chance of this, stated with the estimate: 40%); middle value at least 1.0-fold (0.03 log units) from the limit.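

In this assay, going by these compounds alone, 4-fluorophenyl on a saturated chain carbon bound to an aromatic nitrogen, in place of the group with a five-membered and a six-membered aromatic ring, gives an at least 2.2-fold higher number from compound 3 to compound 4 (0.34 log units; beyond the scatter); this is the first step at this place that lies beyond the scatter. Compound 4 sits at a limit of the assay and not a number, so the step is only a floor: the limit of >= 162 ug/mL in this assay, at which 1 of the 4 values shown sits. The steps from compound 1 and from compound 2 to compound 4 cannot be read, as each joins two limits.

The share of the fluorine in this step cannot be separated from the loss of the five-membered aromatic ring. On these data alone, how an amine or a carboxylic acid in place of the fluorine would read in this assay stays open.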